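Fluorine for methyl on the triazolyl-phenyl of a tosylated core

The compounds below may be only part of what the source reports. "The series", "measured", "known", "first", "only" and "open" are said of these compounds alone.

The measured compounds:
compound 1 `C=C1C[C@]23C[C@@]1(O)CC[C@H]2c1ccc(OS(=O)(=O)c2ccc(C)cc2)c(C)c1[C@@H]3Cn1cc(-c2ccc(Br)cc2)nn1`, in a functional assay on HL-60 cells (Homo sapiens) for cytotoxicity, read by MTT assay, with a stated time of 4 days (a higher number here means a weaker inhibitor, a lower number a stronger inhibitor), compound 1 gives > 20000 nM, which is a limit of the assay.
compound 2 `C=C1C[C@]23C[C@@]1(O)CC[C@H]2c1ccc(OS(=O)(=O)c2ccc(C)cc2)c(C)c1[C@@H]3Cn1cc(-c2ccc(C)cc2)nn1`, in this assay compound 2 gives > 20000 nM, again a limit.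
compound 3 `Cc1c(O)ccc2c1[C@H](Cn1cc(-c3ccc(Cl)cc3)nn1)[C@@]13CC(=O)[C@@](C)(CC[C@@H]21)C3`, in this assay compound 3 gives > 20000 nM, also a limit.

Compound 2 therefore stands at the limit of this assay, with no number of its own, and the two further values shown stand there too. Going by the values given here, the only step between measured compounds, a step that the two limits leave unreadable from compound 1 to compound 2, cannot be read, because both ends sit at the limit; the limit of > 20000 nM in this assay, at which 3 of the 3 values shown sit, sums up all that the evidence offers.

The unmeasured compound 4 `C=C1C[C@]23C[C@@]1(O)CC[C@H]2c1ccc(OS(=O)(=O)c2ccc(C)cc2)c(C)c1[C@@H]3Cn1cc(-c2ccc(F)cc2)nn1` differs from compound 2 in one place: fluoro in place of methyl on an aromatic carbon. This change sits on the same ring as the change from compound 1 to compound 2, which was not readable. With every value at the limit and no readable step, there is no basis to expect compound 4 to move below the limit. The expected step that the limit leaves unreadable from compound 2 to compound 4 is thus none beyond the scatter. Compound 4 is expected to give about 30000 nM, in the range 10000 nM to 100000 nM, most likely again reported only as a limit.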

Compound 4, half-maximal inhibitory concentration: > 20000 nM
Compound 4 gave a limit, no number (the forecaster's own chance of this, stated with the estimate: 80%); the middle value is on the limit's open side.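

Compound 4 sits at the limit, as do compound 1 and compound 2, and no step among these three can be read in this assay. What remains is a single observation: the limit of > 20000 nM in this assay, at which 4 of the 4 values shown sit. The compounds shown leave open how strong each one actually is, and whether any group on that phenyl ring would give a measurable value.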